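Pyrazole variation and antiproliferative effect in one amide series

The source may report more compounds than this note shows. Statements on the series, on what has been measured and on what is new or still open speak of the compounds shown alone.

Measured so far:
Compound 1 `CNC(=O)N1CCCc2ccc(NC(=O)c3cccc(-c4ccn(C(C)=O)n4)c3)cc21` — in a functional assay on MV4-11 cells (Homo sapiens) for antiproliferative activity, with a stated time of 6 days, tested at 1.56 uM (a higher number here means a stronger effect of the compound at the concentration tested, a lower number a weaker effect), compound 1 gives 27.6%.
Compound 2 `CNC(=O)N1CCCc2ccc(NC(=O)c3ccc(-c4ccncc4)cc3)cc21` — compound 2 gives 37.6%.
Compound 3 `CNC(=O)N1CCCc2ccc(NC(=O)c3cccc(-c4cnn(S(C)(=O)=O)c4)c3)cc21` — compound 3 gives 1.6%.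

Compound 3 stands lowest of the three numbers. Among the compounds with values here, the nearest is compound 1, reached by the step of a number 26 percentage points lower from compound 1 to compound 3 (beyond the scatter), the only step of a single change in the set. Within the data shown here, compound 2 lies still further from compound 3 on the values shown; no single-change step joins them.

The next compound, compound 4 `CNC(=O)N1CCCc2ccc(NC(=O)c3cccc(-c4ccn(C)n4)c3)cc21`, differs from compound 3 in one place: 1-methyl-1H-pyrazol-3-yl in place of 1-(methylsulfonyl)-1H-pyrazol-4-yl on an aromatic carbon. This change returns to a pyrazol-3-yl attached as in compound 1, with a methyl on the ring nitrogen where compound 1 bears an acetyl. Among the measured compounds shown here, the only bearing step is the drop from compound 1 to compound 3, which was modest and beyond the scatter. The reverse direction is therefore expected here: a rise of about the same size, a number 26.4 percentage points higher from compound 3 to compound 4 (beyond the scatter), bringing compound 4 back near compound 1. Compound 4 is estimated at 28%, with a range of 12% to 45%.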

Compound 4, a percentage reported as inhibition, at one concentration (the size of the read-out at that concentration, not a potency): 70.5%
Estimate against measurement, compound 4: 42.5 percentage points below; the whole stated range lies below it.
By their numbers in this assay, from the lowest: compound 3; then compounds 1 and 2 (each within the scatter of the next); then compound 4.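

In this assay, methyl in place of acetyl on an aromatic nitrogen gives a number 42.9 percentage points higher from compound 1 to compound 4 (beyond the scatter), with the pyrazol-3-yl attachment unchanged, so the group on the pyrazole nitrogen alone can shift this read-out strongly. The step from the 1-(methylsulfonyl)-1H-pyrazol-4-yl group to the 1-methyl-1H-pyrazol-3-yl group gives a number 68.9 percentage points higher from compound 3 to compound 4 (beyond the scatter), but it alters both the nitrogen group and the attachment, and its size cannot be divided between them. The earlier step between compounds also changed both features, so it could not isolate the nitrogen group.

As far as these compounds go, whether 1-methyl-1H-pyrazol-4-yl would hold this level remains open, as does the effect of ethyl, 2-hydroxyethyl or a free hydrogen on the pyrazole nitrogen. No measurement available here accounts for the size of these steps.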